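Working notes: fluoro to trifluoromethoxy at one aromatic carbon

The compounds below may be only part of what the source reports. "The series", "measured", "known", "first", "only" and "open" are said of these compounds alone.

Compounds measured in a functional assay on A-375 cells (Homo sapiens) for antiproliferative activity, read by MTT assay, with a stated time of 24 h, tested at 0.41 ug/mL; on this read-out lower numbers stand for a weaker effect and higher numbers for a stronger effect at the one concentration tested:

compound 1 `Cc1ccc2nc(C(=O)Nc3c(F)cc(-c4cccc(F)c4)cc3F)c(C)c(O)c2c1` gives 1.35%
compound 2 `CCc1ccc2nc(C(=O)Nc3c(F)cc(-c4cccc(F)c4)cc3F)c(C)c(O)c2c1` gives 3.56%
compound 3 `Cc1c(C(=O)Nc2c(F)cc(-c3cccc(F)c3)cc2F)nc2ccc(F)cc2c1O` gives 0.86%

All three numbers lie close together: a number 2.2 percentage points higher from compound 1 to compound 2 (within the scatter), a number 0.5 percentage points lower from compound 1 to compound 3 (within the scatter) and a number 2.7 percentage points lower from compound 2 to compound 3 (within the scatter). Compound 3 therefore holds the smallest of the three numbers only nominally and is not separated from compound 1 or compound 2 in this assay.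

Compound 4 `Cc1c(C(=O)Nc2c(F)cc(-c3cccc(F)c3)cc2F)nc2ccc(OC(F)(F)F)cc2c1O` differs from compound 3 by trifluoromethoxy in place of fluoro on an aromatic carbon. The two measured steps that touch the same aromatic carbon are a number 0.5 percentage points lower from compound 1 to compound 3 (within the scatter) and a number 2.7 percentage points lower from compound 2 to compound 3 (within the scatter), both exchanges of one small group for another at that position, and neither moved the read-out beyond the scatter. Going by the values given here, no measured step covers a trifluoromethoxy group anywhere, so the expectation rests on those two steps alone.

Because a number 0.5 percentage points lower from compound 1 to compound 3 (within the scatter) and a number 2.7 percentage points lower from compound 2 to compound 3 (within the scatter) stayed within the scatter, the step expected in this assay is a number 1.1 percentage points higher from compound 3 to compound 4 (within the scatter), with no direction claimed beyond the scatter. Compound 4 is accordingly estimated at 2%, within a range from -4% to 9%.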

Compound 4, a percentage reported as inhibition, at one concentration (the size of the read-out at that concentration, not a potency): 1.02%
Beside the measured number, compound 4's estimate is 1 percentage points above it, and the stated range covers the measured number.
By their numbers in this assay, from the lowest: compounds 3, 4, 1 and 2 (each within the scatter of the next).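

Trifluoromethoxy, with 5 heavy atoms against 1 for fluoro and with 1 hydrogen-bond acceptor, widens the range of groups tried at this aromatic carbon, yet in this assay the exchange gives a number 0.2 percentage points higher from compound 3 to compound 4 (within the scatter). Set against the two alkyl groups at the same carbon, the same group gives a number 0.3 percentage points lower from compound 1 to compound 4 (within the scatter) and a number 2.5 percentage points lower from compound 2 to compound 4 (within the scatter). Methyl, ethyl, fluoro and trifluoromethoxy are therefore not told apart at this position at the one concentration tested, so the larger oxygen-linked group adds no separation that the smaller exchanges lacked.

Whether a different kind of group here, such as an amine or a carboxylic acid, would leave the scatter remains open, as does any difference among these four compounds at other concentrations. No supporting data bear on why the read-out stays flat at this position.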